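The source may report more compounds than this note shows. Statements on the series, on what has been measured and on what is new or still open speak of the compounds shown alone.

Compound 1 `O=C(CN1CCCCC1)Nc1ccc(-c2nc3cc(Cl)c(Cl)cc3[nH]2)cc1` is tested in an ADME assay on Vero cells (Chlorocebus sabaeus) for cytotoxicity; on this read-out higher numbers stand for lower toxicity in this test and lower numbers for higher toxicity in this test. In this assay compound 1 gives > 100000 nM, which is a limit of the assay and not a number. Compound 3 `Nc1ccc(-c2nc3cc(Cl)c(Cl)cc3[nH]2)cc1` gives >= 100000 nM, likewise a limit. The step from compound 1 to compound 3, hydrogen in place of ((piperidin-1-yl)methyl)carbonyl on a nitrogen on an aromatic ring, reads a step that the two limits leave unreadable from compound 1 to compound 3; both ends sit at limits, the limit of > 100000 nM in this assay, at which 1 of the 3 values shown sits, and (the limit of >= 100000 nM in this assay, at which 1 of the 3 values shown sits), so its size cannot be read. Within the data shown here, compound 2 `Cn1c(-c2ccc(NC(=O)CN3CCN(c4ccccc4)CC3)cc2)nc2cc(C(F)(F)F)ccc21`, built on a different core, gives 30000 nM in this assay; no single-point step connects it to compound 1, so it shows only that a number within the range of this assay is reached somewhere.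

Compound 4 `CN1CCN(CC(=O)Nc2ccc(-c3nc4cc(Cl)c(Cl)cc4[nH]3)cc2)CC1` is not yet measured. It differs from compound 1 by 4-methylpiperazin-1-yl in place of piperidin-1-yl on a saturated chain carbon bound to a carbonyl carbon. Among the measured compounds shown here, no measured step bears on an exchange of this kind: the only step on the shared core, a step that the two limits leave unreadable from compound 1 to compound 3, is unreadable, and compound 2 carries another core. Compound 1 stands at a limit, so a step towards lower toxicity would stay unreadable, and only a large step towards higher toxicity would yield a number. Compound 4 is therefore expected to stay at or near the limit, with the step of a number no higher from compound 1 to compound 4 (the limit leaves the size open) expected. The estimate for compound 4 is 100000 nM, in the range 50000 nM to 300000 nM.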

Compound 4, half-maximal cytotoxic concentration: > 100000 nM
Compound 4 ended at the assay's limit (the forecaster's own chance of this, stated with the estimate: 70%); the middle value lies on the limit itself.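

Compound 1 and compound 4 both sit at a limit in this assay, so the step between them cannot be read, because both ends stand at the same limit: the limit of > 100000 nM in this assay, at which 2 of the 4 values shown sit.

The compounds shown leave open how far the shared core lies past that limit, and whether any exchange on it gives a number in this assay.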